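The source may report more compounds than this note shows. Statements on the series, on what has been measured and on what is new or still open speak of the compounds shown alone.

Measured so far in a physicochemical assay for lipophilicity, read by HPLC, measured as octanol-water partition, at pH 7.4; on this read-out higher numbers stand for higher lipophilicity and lower numbers for lower lipophilicity

compound 1 `CC1(C)CO[C@H]1CN([C@H](CCC(F)(F)F)C(N)=O)S(=O)(=O)c1ccc(Cl)cc1` gives 3.8
compound 2 `NC(=O)[C@@H](CCC(F)(F)F)N(CC1CCCC1)S(=O)(=O)c1ccc(Cl)cc1` gives 5.15
compound 3 `NC(=O)[C@@H](CCC(F)(F)F)N(C[C@@H]1CCCCO1)S(=O)(=O)c1ccc(Cl)cc1` gives 4.3

On these numbers compound 3 stands second highest, above compound 1 and below compound 2. Compound 4 `NC(=O)[C@@H](CCC(F)(F)F)N(C[C@H]1CCCOC1)S(=O)(=O)c1ccc(Cl)cc1` has the same atoms as compound 3, joined differently (oxan-3-yl in place of oxan-2-yl on a saturated chain carbon bound to a sulfonamide nitrogen), with oxan-3-yl in place of oxan-2-yl on a saturated chain carbon bound to a sulfonamide nitrogen. Going by the values given here, two measured steps touch this place, both modest and both swapping in a different kind of group (a number 0.50 log units higher from compound 1 to compound 3 (beyond the scatter)) and (a number 0.85 log units lower from compound 2 to compound 3 (beyond the scatter)), so for compound 4, which keeps the same atoms, a smaller step in this assay is expected, none beyond the scatter. Among the compounds with values here, no measured pair shows a change of this kind directly. The estimated step is small (a number 0.10 log units lower from compound 3 to compound 4 (within the scatter)). Compound 4 is expected near 4.2 with an estimated range from 3.8 to 4.6.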

Compound 4, distribution coefficient: 3.6
Estimate against measurement, compound 4: 0.60 log units above; the measured number lies below the stated range.
By their numbers in this assay, from the lowest: compounds 4 and 1 (each within the scatter of the next); then compound 3; then compound 2.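

In this assay the two oxane attachments are not interchangeable: with the same atoms, oxan-3-yl in place of oxan-2-yl gives a clear change (a number 0.70 log units lower from compound 3 to compound 4 (beyond the scatter)). The ring's point of attachment alone puts compound 4 level with compound 1, which carries a different ring (a number 0.20 log units lower from compound 1 to compound 4 (within the scatter)), and widens the gap to the cyclopentyl compound (a number 1.55 log units lower from compound 2 to compound 4 (beyond the scatter)). No measured evidence here explains this difference.

The compounds shown leave open where oxan-4-yl would fall. They also leave open whether the same gap appears between oxolan-2-yl and oxolan-3-yl, or with an amine such as piperidin-3-yl.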